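Aryl swap at the core: notes toward compound 4

The source may hold more compounds than are shown below. What is called first, only, known or untested is meant among the compounds shown, and "the series" means these compounds.

Measured so far in a functional assay on NCI-H460 cells (Homo sapiens) for inhibition, read by sulforhodamine B assay, with a stated time of 48 h, tested at 10 uM; a lower number here means less inhibition, a higher number more inhibition at the concentration tested (going by the name of the read-out):
compound 1 `O=Cc1ccc(-c2cn3ccnc3c(-c3ccc4ncn(C5CCCCC5)c4c3)n2)cc1` gives 37.8%
compound 2 `CC(=O)c1ccc(-c2cn3ccnc3c(-c3ccc4ncn(C5CCCCC5)c4c3)n2)cc1` gives 7.12%
compound 3 `Brc1ccc(-c2cn3ccnc3c(-c3ccc4ncn(C5CCCCC5)c4c3)n2)cc1` gives 13.2%

Compound 3 stands second highest of the three numbers. Its nearest neighbour is compound 2, where the step of a number 6.1 percentage points higher from compound 2 to compound 3 (within the scatter) lies within the scatter, so no order between them can be read. Its furthest is compound 1, where the step of a number 24.6 percentage points lower from compound 1 to compound 3 (beyond the scatter) lies beyond the scatter. The remaining measured step, a number 30.7 percentage points lower from compound 1 to compound 2 (beyond the scatter), is also beyond the scatter.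

Compound 4 `Fc1ccccc1-c1cn2ccnc2c(-c2ccc3ncn(C4CCCCC4)c3c2)n1` differs from compound 3 in one place: 2-fluorophenyl in place of 4-bromophenyl on an aromatic carbon. Going by the values given here, none of the measured steps bears directly on this change. Among the compounds with values here, the two steps that touch the aryl ring exchange formyl, acetyl and bromo, and once formyl is gone, as in compound 2 and compound 3, the numbers sit close together; no measured compound carries fluorine or a 2-fluorophenyl. Within the data shown here, with no step in hand that speaks to a 2-fluorophenyl, the expectation for compound 4 is a number near that of compound 3, with no step beyond the scatter expected, that is a number 1.8 percentage points higher from compound 3 to compound 4 (within the scatter). Compound 4 is therefore estimated at 15%, with a range from 0% to 40%, the width reflecting that the new group is unrepresented among the measured compounds.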

Compound 4, a percentage reported as inhibition, at one concentration (the size of the read-out at that concentration, not a potency): 8.1%
Compound 4: middle estimate off by 6.9 percentage points, on the high side, within the range that was stated.
By their numbers in this assay, from the lowest: compounds 2, 4 and 3 (each within the scatter of the next); then compound 1.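

In this assay, exchanging the 4-bromophenyl for a 2-fluorophenyl on the aromatic carbon next to the ring nitrogen gives a step within the scatter (a number 5.1 percentage points lower from compound 3 to compound 4 (within the scatter)), and the same holds against the 4-acetylphenyl (a number 1 percentage points higher from compound 2 to compound 4 (within the scatter)), so compound 2, compound 3 and compound 4 cannot be ordered even though the aryl substituent differs in identity and in its place on the ring. Going by these compounds alone, compound 1 stays apart from this new aryl as well (a number 29.7 percentage points lower from compound 1 to compound 4 (beyond the scatter)), which leaves the 4-formylphenyl as the only aryl group among the four whose number stands beyond the scatter from all the others. No measurement at hand offers an explanation for these numbers.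

The step from compound 3 to compound 4 changes the halogen and its place on the aryl ring together, so the compounds shown do not separate these two changes. Nor do they show whether the higher number of compound 1 is particular to the formyl group or would also appear with another group in its place, such as a carboxylic acid or an aminomethyl group.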